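A few compounds are considered here, and "the series" means these few. Any claim that something is new, unique, unknown or untested is made for them only; others in the source may bear on it.

Going by the values given here, compound 1, `CCCCCc1ccc(C(=O)O[C@@H]2CCC(NC(=O)[C@H](OC)[C@H](O)[C@@H](O)[C@H](O)/C=C/C(C)(C)C)C(=O)NC2)cc1`, is one of three compounds measured in an in vivo functional assay on the whole organism (MDA-MB-435 cells, Homo sapiens) for antiproliferative activity (a lower number here means a stronger inhibitor, a higher number a weaker inhibitor), where compound 1 gives 20 nM. It stands second highest of the three numbers: compound 2, `CCCCCCCCCCCCCC(=O)O[C@H]1CCC(NC(=O)[C@H](OC)[C@H](O)[C@@H](O)[C@H](O)/C=C/C(C)(C)C)C(=O)N(C)C1`, gives 10 nM, within the scatter of compound 1, while compound 3, `CO[C@@H](C(=O)NC1CC[C@@H](OC(=O)CC2CCCCC2)CNC1=O)[C@H](O)[C@@H](O)[C@H](O)/C=C/C(C)(C)C`, gives 60 nM, the furthest from compound 1 and beyond the scatter.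

The unmeasured compound 4, `CO[C@@H](C(=O)NC1CC[C@@H](OC(=O)C2CCCCC2)CNC1=O)[C@H](O)[C@@H](O)[C@H](O)/C=C/C(C)(C)C`, differs from compound 1 in one place: cyclohexyl in place of 4-pentylphenyl on a carbonyl carbon.

Among the compounds with values here, one measured step bears on this change. The step of a 3.0-fold higher number from compound 1 to compound 3 (0.48 log units; beyond the scatter) replaced the same 4-pentylphenyl group on the same carbonyl carbon with cyclohexylmethyl, a saturated ring one carbon longer than the cyclohexyl group entering compound 4. That step was modest and beyond the scatter. A step of similar size and direction is therefore expected for compound 4, so that the estimated step is a 3.0-fold higher number from compound 1 to compound 4 (0.48 log units; beyond the scatter). In this assay compound 4 is estimated at 60 nM, with a range from 25 nM to 150 nM.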

Compound 4, half-maximal inhibitory concentration: 4 nM
The estimate for compound 4 lay 15-fold (1.18 log units) above the measured number; measured number below the stated range.
By their numbers in this assay, from the lowest: compound 4; then compounds 2 and 1 (each within the scatter of the next); then compound 3.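

Putting cyclohexyl in place of 4-pentylphenyl on this carbonyl carbon gave a 5.0-fold lower number from compound 1 to compound 4 (0.70 log units; beyond the scatter) in this assay, the opposite direction to a 3.0-fold higher number from compound 1 to compound 3 (0.48 log units; beyond the scatter), so saturated rings at this position do not share a single direction of change. The difference between cyclohexylmethyl and cyclohexyl alone gave a 15-fold lower number from compound 3 to compound 4 (1.18 log units; beyond the scatter), the largest step among these compounds, which shows that this position separates even these two closely related groups. Nothing measured here explains the difference between them.

On these data alone, it remains open whether a cyclopentyl or cyclopropyl ring, or a plain phenyl lacking the pentyl chain, would follow cyclohexyl or 4-pentylphenyl in this assay. Also unsettled is how a cyclohexyl ring carrying an amine or a carboxylic acid would behave on the same carbonyl carbon.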